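Fluoro to chloro on the urea aryl ring

The compounds below may be only part of what the source reports. "The series", "measured", "known", "first", "only" and "open" are said of these compounds alone.

Measured in a functional assay on SW-620 cells (Homo sapiens) for inhibition, read by MTT assay, with a stated time of 72 h (on this read-out lower numbers stand for stronger inhibition and higher numbers for weaker inhibition), so far:
compound 1 `COc1cc(NC(C)CCCNC(=O)Nc2cccc(F)c2)c2ncccc2c1` gives 27000 nM
compound 2 `COc1cc(NC(C)CCCNC(=O)Nc2ccc(F)cc2)c2ncccc2c1` gives 25000 nM
compound 3 `COc1cc(NC(C)CCCNC(=O)NNC(=O)Nc2cccc(C(F)(F)F)c2)c2ncccc2c1` gives 21000 nM

Compound 2, at 25000 nM, lies within the scatter of both compound 1 and compound 3, so no order can be read among the three.

Not yet measured is compound 4 `COc1cc(NC(C)CCCNC(=O)Nc2ccc(Cl)cc2)c2ncccc2c1`, which carries chloro in place of fluoro on an aromatic carbon, para to a large group: chloro in place of fluoro on an aromatic carbon. Among the measured compounds shown here, the one measured step that bears on this is a 1.1-fold lower number from compound 1 to compound 2 (0.03 log units; within the scatter), which exchanges 3-fluorophenyl for 4-fluorophenyl and stays within the scatter. For the measured compounds named here, no measured pair exchanges one halogen for another, so this evidence is indirect. With so small a step on the fluorophenyl group, no change beyond the scatter is expected in this assay.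

The estimated step is a 1.1-fold lower number from compound 2 to compound 4 (0.06 log units; within the scatter) and remains small.

For compound 4 the expected value is 22000 nM, with an estimated range of 12000 nM to 38000 nM.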

Compound 4, half-maximal inhibitory concentration: 28000 nM
For compound 4 the middle estimate is 1.3-fold (0.10 log units) below the measured one; low and high end bracket the measured number.
By their numbers in this assay, from the lowest: compounds 3, 2, 1 and 4 (each within the scatter of the next).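

Chloro in place of fluoro on an aromatic carbon, para to a large group, gives a 1.1-fold higher number from compound 2 to compound 4 (0.05 log units; within the scatter) in this assay and is the first direct exchange of one halogen for another on this ring. The wider change from 3-fluorophenyl to 4-chlorophenyl, which alters both the halogen and its place, gives a 1.0-fold higher number from compound 1 to compound 4 (0.02 log units; within the scatter) and so also stays within the scatter. Nothing available on these compounds offers an account of this result.

The halogen steps therefore show no effect on the number, and the compounds shown do not tell whether any group at this place can move it beyond the scatter. On these data alone, whether an amine or a carboxylic acid in place of the halogen, or a longer chain on the shared core, would do so remains open.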